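Removing Both Chlorines from the Benzyl Group of Compound 3

A few compounds are considered here, and "the series" means these few. Any claim that something is new, unique, unknown or untested is made for them only; others in the source may bear on it.

Measured compounds:
Compound 1 `CCn1c(=O)n(C2OC(CO)[C@@H](O)[C@H]2O)c2nc(N)nc(O)c21` gives 82% in a functional assay on the whole organism (B cells) with Mus musculus as the target; a higher number here means a larger maximal response, a lower number a smaller maximal response.
Compound 2 `COc1ccc(Cn2c(=O)n(C3OC(CO)[C@@H](O)[C@H]3O)c3nc(N)nc(O)c32)cc1` gives 44% in this assay.
Compound 3 `Nc1nc(O)c2c(n1)n(C1OC(CO)[C@@H](O)[C@H]1O)c(=O)n2Cc1ccc(Cl)c(Cl)c1` gives 55% in this assay.

Compound 3 stands second highest of the three. Its nearest neighbour is compound 2, as the step of a number 11 percentage points higher from compound 2 to compound 3 (beyond the scatter) shows; the furthest is compound 1, as the step of a number 27 percentage points lower from compound 1 to compound 3 (beyond the scatter) shows. Both compounds carrying a benzyl group therefore sit clearly under the ethyl compound, and the step of a number 38 percentage points lower from compound 1 to compound 2 (beyond the scatter) confirms this for the other benzyl variant.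

Compound 4 `Nc1nc(O)c2c(n1)n(C1OC(CO)[C@@H](O)[C@H]1O)c(=O)n2Cc1ccccc1` differs from compound 3 by phenyl in place of 3,4-dichlorophenyl on a saturated chain carbon bound to an aromatic nitrogen. The step that bears most directly on this change is a number 11 percentage points higher from compound 2 to compound 3 (beyond the scatter), where exchanging one substituted phenyl for another moved the maximal response only modestly. Removing both chlorines is expected to stay within that span, so the step of a number 5 percentage points lower from compound 3 to compound 4 (within the scatter) is estimated to be small, probably slightly downward and possibly within the scatter. Compound 4 is thus expected to reach about 50% in this assay, within a range from 35% to 65%.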

Compound 4, largest response reached (reported as maximal response), in percent of the reference or control that the assay uses: 110%
Compound 4: middle estimate off by 60 percentage points, on the low side; measured number outside the range, above it.
By their numbers in this assay, from the lowest: compound 2; then compound 3; then compound 1; then compound 4.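

At this place, on a saturated chain carbon bound to an aromatic nitrogen, a phenyl ring does not by itself go with a lower response: the change from methyl to phenyl gives a number 28 percentage points higher from compound 1 to compound 4 (beyond the scatter) in this assay and runs opposite to the steps seen with both substituted rings. The lower numbers go with the substituents on the ring, since phenyl in place of 3,4-dichlorophenyl gives a number 55 percentage points higher from compound 3 to compound 4 (beyond the scatter) and hydrogen in place of methoxy gives a number 66 percentage points higher from compound 2 to compound 4 (beyond the scatter) as the largest step of the set. Nothing available here accounts for these jumps.

The compounds shown leave open whether a single chlorine or a single fluorine on the phenyl ring already lowers the response. Also open, as far as these compounds go, is whether a longer chain carrying the phenyl ring keeps the number as high as that of compound 4.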